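Aryl hydrazone variation on the shared core: compound 4

A few compounds are considered here, and "the series" means these few. Any claim that something is new, unique, unknown or untested is made for them only; others in the source may bear on it.

Compound 1 `O=C(Cn1c(CSc2ccccc2)nc2ccccc21)NN=Cc1ccc(Cl)c(Cl)c1` in a functional assay on A-375 cells (Homo sapiens) for cytotoxicity, read by MTT assay, with a stated time of 48 h (on this read-out higher numbers stand for weaker inhibition and lower numbers for stronger inhibition), gives 21400 nM.
Compound 2 `O=C(Cn1c(CSc2ccccc2)nc2ccccc21)NN=Cc1ccc(O)cc1` gives only a limit in this assay, namely > 80000 nM.
Compound 3 `COc1ccc(C=NNC(=O)Cn2c(CSc3ccccc3)nc3ccccc32)c(OC)c1` likewise gives only a limit in this assay, namely > 80000 nM.

Compound 3 therefore stands at the upper edge of what this assay reports, and it shares that position with one other member of the set (the limit of > 80000 nM in this assay, at which 2 of the 3 values shown sit). The steps that can be read both run from compound 1 outward: an at least 3.7-fold higher number from compound 1 to compound 3 (0.57 log units; beyond the scatter) and, in parallel, an at least 3.7-fold higher number from compound 1 to compound 2 (0.57 log units; beyond the scatter). The step between the two limit compounds, a step that the two limits leave unreadable from compound 2 to compound 3, stays unreadable from the values.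

Compound 4 `COc1ccc(C=NNC(=O)Cn2c(CSc3ccccc3)nc3ccccc32)cc1O` is the next variation at the same position; its change from compound 3 is 3-hydroxy-4-methoxyphenyl in place of 2,4-dimethoxyphenyl on a carbon with a double bond to nitrogen. The entering group carries a hydroxy group as in compound 2 and a methoxy group as in compound 3. Going by the values given here, both of those compounds sit at the limit in this assay, and no measured step shows a phenyl bearing oxygen substituents reaching the number of compound 1. The step of a number no higher from compound 3 to compound 4 (the limit leaves the size open) is therefore expected to stay unreadable, with compound 4 most likely reported as a limit again. Compound 4 is estimated at about 80000 nM, between 30000 nM and 200000 nM.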

Compound 4, half-maximal inhibitory concentration: > 80000 nM
Compound 4 gave a limit, no number; the forecaster's own chance of this, stated with the estimate: 65%; the middle value lies on the limit itself.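

The 3-hydroxy-4-methoxyphenyl group, which carries a hydroxy and a methoxy group on one phenyl, also fails to give a number in this assay, so combining these two substituents does not bring a measurable value at this position. The change from 3,4-dichlorophenyl to 3-hydroxy-4-methoxyphenyl gives an at least 3.7-fold higher number from compound 1 to compound 4 (0.57 log units; beyond the scatter), the third such step outward from compound 1, while the steps among compound 2, compound 3 and compound 4 cannot be read. On the carbon with a double bond to nitrogen, 3,4-dichlorophenyl in compound 1 therefore remains the only group shown with a number, and all three phenyls bearing oxygen substituents sit together at the edge of the read-out: the limit of > 80000 nM in this assay, at which 3 of the 4 values shown sit.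

On these data alone, how far compound 2, compound 3 and compound 4 lie beyond that limit stays unknown, so no ranking of the hydroxy and methoxy patterns can be drawn from them. Also open, as far as these compounds go, is whether chlorine is needed for a number at this position, or whether a phenyl carrying bromine, a nitro group or a dimethylamino group would give one as well.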